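Methyl to fluorine on the pendant phenyl ring

The source may report more compounds than this note shows. Statements on the series, on what has been measured and on what is new or still open speak of the compounds shown alone.

Measured so far:
compound 1, `O=[N+]([O-])c1ccc(N/C(=N\O)c2ccccc2Br)c2nonc12`: 80 nM
compound 2, `O=[N+]([O-])c1ccc(N/C(=N\O)c2cccc(Cl)c2)c2nonc12`: 184 nM
compound 3, `Cc1ccc(/C(=N/O)Nc2ccc([N+](=O)[O-])c3nonc23)cc1`: 204 nM

All three compounds share one core and differ only in the phenyl group on the carbon with a double bond to nitrogen. In an assay on isolated protein for inhibition of Indoleamine 2,3-dioxygenase 1 (Homo sapiens), read by spectrophotometry, with a stated time of 1 h (on this read-out lower numbers stand for stronger inhibition and higher numbers for weaker inhibition), compound 1 gives 80 nM. Compound 2 gives 184 nM, and compound 3 gives 204 nM, the highest of the three numbers. The steps of a 2.3-fold higher number from compound 1 to compound 2 (0.36 log units; beyond the scatter) and a 2.6-fold higher number from compound 1 to compound 3 (0.41 log units; beyond the scatter) both exceed the scatter, whereas a 1.1-fold higher number from compound 2 to compound 3 (0.04 log units; within the scatter) lies within it, so compound 2 and compound 3 cannot be told apart on these numbers.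

Compound 4, `O=[N+]([O-])c1ccc(N/C(=N\O)c2ccc(F)cc2)c2nonc12`, differs from compound 3 by fluoro in place of methyl on an aromatic carbon. Within the data shown here, none of the measured steps exchanges one group for another at this same position, so no step bears directly on it; the only comparison is that compound 2 and compound 3, which carry different single substituents on the phenyl ring, sit within the scatter of each other. On that basis compound 4 is expected to stay close to compound 3, with a step of a 1.0-fold lower number from compound 3 to compound 4 (0.01 log units; within the scatter) that should not exceed the scatter. The estimate for compound 4 in this assay is 200 nM, with a range from 90 nM to 450 nM.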

Compound 4, half-maximal inhibitory concentration: 100 nM
The estimate for compound 4 lay 2.0-fold (0.30 log units) above the measured number; the measured number falls inside the stated range.
By their numbers in this assay, from the lowest: compounds 1, 4, 2 and 3 (each within the scatter of the next, the first and the last beyond it).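

In this assay, among these compounds, replacing methyl with fluoro on the aromatic carbon para to a large group gives a modest change that lies beyond the scatter (a 2.0-fold lower number from compound 3 to compound 4 (0.31 log units; beyond the scatter)), so this position responds to the exchange of one heavy atom, which the earlier compounds could not show. The 4-fluorophenyl group cannot be told apart from either of the other two phenyl groups, as the steps to it from 3-chlorophenyl (a 1.8-fold lower number from compound 2 to compound 4 (0.26 log units; within the scatter)) and from 2-bromophenyl (a 1.3-fold higher number from compound 1 to compound 4 (0.10 log units; within the scatter)) both stay within the scatter, so only 4-methylphenyl separates from compound 4. Nothing available here accounts for the change between methyl and fluoro.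

The compounds shown leave open whether chloro, methoxy or a carboxylic acid on this same aromatic carbon would sit with compound 3, with compound 4 or apart from both. They also leave open how much of the difference between compound 1 and compound 3 comes from the bromine itself and how much from where it sits on the ring.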